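This account rests on a few compounds, and the source may have more. Where it says the series, first, only, none or still open, it means among the compounds named here.

The compounds in this set share one core and differ in the aryl groups attached to it. Compound 1 `COc1cccc(-c2nc3c(-c4ccco4)n[nH]c3c(=O)n2NC(=O)c2cccnc2)c1` was tested in a functional assay on A549 cells (Homo sapiens) for cytotoxicity, read by sulforhodamine B assay, with a stated time of 2 days, tested at 100 uM (a lower number here means less inhibition, a higher number more inhibition at the concentration tested (going by the name of the read-out)), where compound 1 gives 14.9%. Compound 2 `COc1cccc(-c2nc3c(-c4cccc(Cl)c4)n[nH]c3c(=O)n2NC(=O)c2ccccc2)c1` belongs to the same set, but for compound 2 the entry in this assay reads "not determined" (no result reported), so no number exists for it. Compound 3 `O=C(Nn1c(-c2cccc([N+](=O)[O-])c2)nc2c(-c3ccco3)n[nH]c2c1=O)c1ccccc1` gives 18.7% in this assay. Among the compounds with values here, only two numbers are therefore available, and the gap between compound 3 and compound 1 lies within the usual scatter of such measurements, so the two numbers can only be called level on this evidence; both sit at the low end of the read-out.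

Compound 4 `COc1cccc(-c2nc3c(-c4ccco4)n[nH]c3c(=O)n2NC(=O)c2ccccc2)c1` has not yet been measured. It differs from compound 3 in one place: methoxy in place of nitro on an aromatic carbon. Compound 1 also carries a methoxy group and reads low, and compound 3 with its nitro group reads low as well, so these two numbers give no sign that the exchange matters for this read-out. The step in this assay is expected to be small, with no change beyond the scatter in either direction: a number 3.7 percentage points lower from compound 3 to compound 4 (within the scatter). Compound 4 is accordingly expected to give 15%, with a range from 4% to 28%.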

Compound 4, a percentage reported as inhibition, at one concentration (the size of the read-out at that concentration, not a potency): 53.8%
For compound 4 the middle estimate is 38.8 percentage points below the measured one; the whole stated range lies below it.
By their numbers in this assay, from the lowest: compounds 1 and 3 (each within the scatter of the next); then compound 4.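

In this assay, the exchange of 3-nitrophenyl for 3-methoxyphenyl gives a number 35.1 percentage points higher from compound 3 to compound 4 (beyond the scatter), so the group on this aromatic carbon does bear on the read-out, which compounds 1 and 3 could not show, differing as they do in two places. The other end of the molecule responds as well: phenyl in place of pyridin-3-yl on the carbonyl carbon gives a number 38.9 percentage points higher from compound 1 to compound 4 (beyond the scatter), so neither the methoxy group nor the phenyl group alone accounts for the higher number, and among the compounds with a number, only compound 4 carries both. Nothing given here offers a reason for either step.

The compounds shown contain no pairing of nitro with pyridin-3-yl, so it stays open whether the two exchanges act independently or only together. Also open, going by these compounds, is how far the step depends on methoxy itself, since an amine, a carboxylic acid, a longer ether chain or plain hydrogen at this aromatic carbon does not appear among them.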